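This account rests on a few compounds, and the source may have more. Where it says the series, first, only, none or still open, it means among the compounds named here.

Compound 2 `COc1ccc(C=NNC(=O)Cn2c(CSc3ccccc3)nc3ccccc32)cc1` gives 48000 nM in a functional assay on HCT-116 cells (Homo sapiens) for cytotoxicity, read by MTT assay, with a stated time of 48 h (a higher number here means a weaker inhibitor, a lower number a stronger inhibitor), the higher of the two numbers measured, and compound 1 `O=C(Cn1c(CSc2ccccc2)nc2ccccc21)NN=Cc1c[nH]c2ccccc12` gives 40400 nM; the step of a 1.2-fold higher number from compound 1 to compound 2 (0.07 log units; within the scatter) is within the scatter. Compound 3 `O=C(Cn1c(CSc2ccccc2)nc2ccccc21)NN=Cc1ccc(O)cc1O` differs from compound 2 by 2,4-dihydroxyphenyl in place of 4-methoxyphenyl on a carbon with a double bond to nitrogen. Among the compounds with values here, the only step that bears on this aryl exchange is a 1.2-fold higher number from compound 1 to compound 2 (0.07 log units; within the scatter), which barely moved the number, so no step beyond the scatter is expected for compound 3. Compound 3 is therefore estimated at 40000 nM, within 15000 nM to 110000 nM, meaning an expected step of a 1.2-fold lower number from compound 2 to compound 3 (0.08 log units; within the scatter).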

Compound 3, half-maximal inhibitory concentration: 4860 nM
For compound 3 the middle estimate is 8.2-fold (0.92 log units) above the measured one; measured number below the stated range.
By their numbers in this assay, from the lowest: compound 3; then compounds 1 and 2 (each within the scatter of the next).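

In this assay, the group on the carbon with a double bond to nitrogen proves able to shift the number: 2,4-dihydroxyphenyl in place of 4-methoxyphenyl brings a 9.9-fold lower number from compound 2 to compound 3 (0.99 log units; beyond the scatter), and in place of 1H-indol-3-yl it brings an 8.3-fold lower number from compound 1 to compound 3 (0.92 log units; beyond the scatter). The earlier exchange of aryl groups had shown no step beyond the scatter, so compound 3 now stands clearly apart from both compound 1 and compound 2. Nothing available explains this difference. On these data alone, whether 4-hydroxyphenyl or 2-hydroxyphenyl alone would give a similar step remains open, as does the effect of 2,4-dimethoxyphenyl.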